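Swapping the Ring on the Thiocarbonyl Carbon of Compound 2

The compounds below may be only part of what the source reports. "The series", "measured", "known", "first", "only" and "open" are said of these compounds alone.

Three compounds have been measured in a functional assay on HeLa cells (Homo sapiens) for antiproliferative activity, read by MTT assay, with a stated time of 72 h; a lower number here means a stronger inhibitor, a higher number a weaker inhibitor:
- compound 1 `CCOC(=O)c1cc(=O)c2cc(CSC(=S)N(C)c3ccccc3)ccc2o1` gives 18100 nM
- compound 2 `O=c1c(CSC(=S)N2CCOCC2)coc2cc(Cl)ccc12` gives 2000 nM
- compound 3 `Cc1ccc2c(=O)c(CSC(=S)N3CCOCC3)coc2c1` gives 6100 nM

Compound 2 has the lowest number of the three, and both of its gaps to the others lie beyond the scatter. Within the data shown here, the one step between compounds that differ in a single place is a 3.1-fold higher number from compound 2 to compound 3 (0.48 log units; beyond the scatter), a change on the aromatic ring of the shared core. Compound 1 differs from compound 2 in several places at once, so only its own value and that of compound 2 can be compared.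

Compound 4 `O=c1c(CSC(=S)N2CCCC2)coc2cc(Cl)ccc12` is built from compound 2 by one change: pyrrolidin-1-yl in place of morpholin-4-yl on a thiocarbonyl carbon. Among the measured compounds shown here, no measured step touches this part of the molecule, so the only guide is that compound 2 is the best of the measured set and the rest of its structure is kept. With nothing pointing either way, the change is expected to give no shift beyond the scatter, a 1.1-fold higher number from compound 2 to compound 4 (0.04 log units; within the scatter). Compound 4 is therefore expected to give about 2200 nM in this assay, within 700 nM to 7000 nM.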

Compound 4, half-maximal inhibitory concentration: 1300 nM
Compound 4: middle estimate off by 1.7-fold (0.23 log units), on the high side; measured number inside the range.
By their numbers in this assay, from the lowest: compounds 4 and 2 (each within the scatter of the next); then compound 3; then compound 1.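

Among these compounds, the step in this assay is a 1.5-fold lower number from compound 2 to compound 4 (0.19 log units; within the scatter) and gives the only measured look at the ring on the thiocarbonyl carbon: here, that ring can be exchanged with no shift beyond the scatter. Compound 2 and compound 4 cannot be told apart in this assay, even though the six-membered ring with its oxygen has given way to a five-membered ring without one. No measurement is available to explain why the two rings read alike.

Ring size and the ring oxygen change together in this single step, so their separate contributions stay unknown; piperidin-1-yl or an open-chain diethylamino group on the same core would bear on that. Also open, as far as these compounds go, is whether pyrrolidin-1-yl would read the same on the methyl-bearing core of compound 3.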